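The source may hold more compounds than are shown below. What is called first, only, known or untested is meant among the compounds shown, and "the series" means these compounds.

Measured so far:
compound 1 `O=C(O)c1ccc(C(F)(F)F)cc1-c1ccc2c(c1)OC[C@H](Cc1ccc(-c3ccccc3)cc1)[C@H]2O`; in a functional assay with leukotriene B4 receptor (Homo sapiens) as the target (on this read-out lower numbers stand for stronger inhibition and higher numbers for weaker inhibition), compound 1 gives 120 nM; 820 nM (2 entries)
compound 2 `O=C(O)c1c(F)cccc1-c1ccc2c(c1)OC[C@H](Cc1ccccc1)[C@H]2O`; in this assay compound 2 gives 400 nM
compound 3 `O=C(O)c1c(F)cc(F)cc1-c1ccc2c(c1)OC[C@H](Cc1ccccc1)[C@H]2O`; in this assay compound 3 gives 300 nM

Compound 2 holds the highest of the two single numbers; its nearest neighbour is compound 3, with a 1.3-fold lower number from compound 2 to compound 3 (0.12 log units; within the scatter). Compound 1 has no single number, only (the several entries of compound 1 in this assay, 120 nM; 820 nM (2 entries)).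

Compound 4 `O=C(O)c1c(-c2ccc3c(c2)OC[C@H](Cc2ccccc2)[C@H]3O)cccc1C(F)(F)F` differs from compound 2 by trifluoromethyl in place of fluoro on an aromatic carbon. Within the data shown here, the only measured step, from compound 2 to compound 3, adds a fluoro at another place and stays within the scatter, so it gives no direct guide to this exchange. No shift beyond the scatter in this assay is therefore expected. Compound 4 is estimated at 300 nM, between 100 nM and 1000 nM, meaning an expected step of a 1.3-fold lower number from compound 2 to compound 4 (0.12 log units; within the scatter).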

Compound 4, half-maximal inhibitory concentration: 750 nM
Compound 4: middle estimate off by 2.5-fold (0.40 log units), on the low side; low and high end bracket the measured number.
By their numbers in this assay, from the lowest: compounds 3, 2 and 4 (each within the scatter of the next, the first and the last beyond it).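

In this assay, trifluoromethyl in place of fluoro, ortho to a carboxy group, gives a 1.9-fold higher number from compound 2 to compound 4 (0.27 log units; within the scatter), so this position accepts a group of 4 heavy atoms in place of 1 without a shift beyond the scatter. Among these compounds, this is the first read at this place, since the earlier fluoro step concerned another position. No measurement shown accounts for the size of this step.

Open, as far as these compounds go, is how an amine or a nitrile would read at this place. Also open, from the compounds shown here alone, is whether the same exchange reads alike on the core of compound 1.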